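This account rests on a few compounds, and the source may have more. Where it says the series, first, only, none or still open, it means among the compounds named here.

Measured compounds in a functional assay on A-431 cells (Homo sapiens) for cytotoxicity, read by MTT assay, with a stated time of 72 h, tested at 10 uM; on this read-out higher numbers stand for more inhibition of growth at the one concentration tested and lower numbers for less inhibition of growth:

Compound 1, `N/C(=N\NC(=S)N1CCCCCC1)c1ccccn1`, gives 67%.
Compound 2, `N/C(=N\NC(=S)N1CCOCC1)c1ccccn1`, gives 69.4%.
Compound 3, `N/C(=N\NC(=S)N1CCOCC1)c1ccc(F)cn1`, gives 66.9%.

Compound 2 and compound 3 share a core; the change between them is fluoro in place of hydrogen on an aromatic carbon, and the step it made is a number 2.5 percentage points lower from compound 2 to compound 3 (within the scatter). The difference between the core of compound 1 and the core of compound 2 is not broken down here. Compound 1 and compound 2 lie within the scatter of each other in this assay , as do compound 1 and compound 3.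

Compound 4, `N/C(=N\NC(=S)N1CCCCCC1)c1ccc(F)cn1`, is not yet measured. Against compound 1 the change is fluoro in place of hydrogen on an aromatic carbon, the same change as from compound 2 to compound 3, made on the core of compound 1 instead. Since that change left compound 2 and compound 3 within the scatter of each other, the expected step from compound 1 to compound 4 is a number 2 percentage points lower from compound 1 to compound 4 (within the scatter), i.e. no step beyond the scatter. For compound 4 in this assay the estimate is 65%, expected to fall between 55% and 75%.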

Compound 4, percent growth inhibition at one concentration: 64.4%
For compound 4 the middle estimate is 0.6 percentage points above the measured one, and the stated range covers the measured number.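

In this assay, fluoro in place of hydrogen on an aromatic carbon gives a number 2.6 percentage points lower from compound 1 to compound 4 (within the scatter). The change carries from one core to the other with no difference beyond the scatter: the same change on two cores in this assay, a number 2.5 percentage points lower (within the scatter) from compound 2 to compound 3 and a number 2.6 percentage points lower (within the scatter) from compound 1 to compound 4, 0.1 percentage points apart, within the scatter of two such steps. For the compounds shown here, since both steps lie within the scatter, this shows only that the change has no readable effect on these two cores at the one concentration tested; it does not show that a step of real size would transfer, or that the same would hold on any other core.

The compounds shown leave open whether a chloro, a methoxy, an amine or a carboxylic acid in that same place, two atoms from the ring nitrogen, would move the read-out beyond the scatter. They also leave open whether fluoro elsewhere on the ring would behave as it does here, since every fluoro compound shown carries it in this one place.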